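Biaryl sulfonamide series: cytotoxicity with only assay limits so far

This account rests on a few compounds, and the source may have more. Where it says the series, first, only, none or still open, it means among the compounds named here.

Compound 1 `CC1CCN(C2CCN(S(=O)(=O)c3cccc(-c4ccccc4C(F)(F)F)c3)CC2)CC1` has been run in an ADME assay on HCT-116 cells (Homo sapiens) for cytotoxicity, read by CellTiter-Glo, with a stated time of 72 h (a higher number here means a weaker inhibitor, a lower number a stronger inhibitor), and returns only a limit, > 5000 nM, not a number. Compound 2 `Cc1c(C)c(S(=O)(=O)N2CCC(N3CCC(C)CC3)CC2)c(C)c2c1OC(C)(C)C2` likewise returns only a limit in this assay, > 10000 nM. Among the compounds with values here, compound 1 therefore stands at an assay limit, and the one other value is a limit too. Compound 3 `COc1ccc(-c2cccc(S(=O)(=O)N3CCC(N4CCC(C)CC4)CC3)c2)cc1` changes compound 1 in one place: 4-methoxyphenyl in place of 2-(trifluoromethyl)phenyl on an aromatic carbon. In this assay a step that the limit leaves unreadable from compound 1 to compound 3 is expected, which is none beyond the scatter. Compound 3 is estimated at 8000 nM, within 3000 nM to 30000 nM, and is expected to come back as a limit again.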

Compound 3, half-maximal inhibitory concentration: > 5000 nM
Compound 3: a limit, no number (the forecaster's own chance of this, stated with the estimate: 70%); the middle value does not contradict the limit.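

In this assay compound 1 and compound 3 both return limits, not numbers, and the step between them cannot be read. The compounds shown leave open whether 4-methoxyphenyl and 2-(trifluoromethyl)phenyl differ at all in this assay.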